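A few compounds are considered here, and "the series" means these few. Any claim that something is new, unique, unknown or untested is made for them only; others in the source may bear on it.

Values in a functional assay on cardiac atrium (Cavia porcellus); on this read-out higher numbers stand for an effect only at larger amounts of compound and lower numbers for an effect already at smaller amounts:
- Compound 1 `COC(=O)C1=C(C)NC(C)=C(C(=O)OC)C1c1c(-c2cccnc2)nc2sc(C)cn12`: 12500 nM
- Compound 2 `COC(=O)C1=C(C)NC(C)=C(C(=O)OC)C1c1c(-c2ccsc2)nc2sc(C)cn12`: 2300 nM
- Compound 3 `COC(=O)C1=C(C)NC(C)=C(C(=O)OC)C1c1c(-c2ccccn2)nc2sc(C)cn12`: 39900 nM

Compound 3 has the highest number of the three, so it needs the largest amount of compound to show an effect. Compound 1 lies nearest to it, and compound 2 lies furthest away.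

Compound 4 `COC(=O)C1=C(C)NC(C)=C(C(=O)OC)C1c1c(-c2ccncc2)nc2sc(C)cn12` is still unmeasured. It differs from compound 3 by pyridin-4-yl in place of pyridin-2-yl on an aromatic carbon, with pyridin-4-yl in place of pyridin-2-yl on an aromatic carbon.

The closest evidence is the swap between two pyridine-based groups, a 3.2-fold higher number from compound 1 to compound 3 (0.50 log units; beyond the scatter), a modest step beyond the scatter. The step of a 17-fold higher number from compound 2 to compound 3 (1.24 log units; beyond the scatter) is large, but it starts from a thiophene-based group, so it bears less directly on this change. Going by the values given here, no measured compound carries pyridin-4-yl, so the direction remains uncertain. Still, compound 3 at 39900 nM is the top of the measured numbers, which favours a modest move downward. The expected change is a 2.7-fold lower number from compound 3 to compound 4 (0.42 log units; beyond the scatter). Compound 4 is estimated at 15000 nM, with an expected range from 4500 nM to 45000 nM.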

Compound 4, half-maximal effective concentration: 7490 nM
Compound 4: middle estimate off by 2.0-fold (0.30 log units), on the high side; the measured number falls inside the stated range.
By their numbers in this assay, from the lowest: compound 2; then compounds 4 and 1 (each within the scatter of the next); then compound 3.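

In this assay, pyridin-4-yl in place of pyridin-2-yl gives a 5.3-fold lower number from compound 3 to compound 4 (0.73 log units; beyond the scatter), so the same atoms joined differently at this place on the shared core shift the number beyond the scatter. The step of a 1.7-fold lower number from compound 1 to compound 4 (0.22 log units; within the scatter) lies within the scatter, which means pyridin-3-yl and pyridin-4-yl cannot be told apart here, and among the three pyridine groups only pyridin-2-yl stands apart. Thiophen-3-yl keeps the lowest number of the set, with a 3.3-fold higher number from compound 2 to compound 4 (0.51 log units; beyond the scatter).

The compounds shown give no information on why moving the ring nitrogen changes the number. Also open, from the compounds shown here alone, is how a plain phenyl ring, or a pyridin-4-yl ring carrying an amine or a methoxy group, would behave at this place.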